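Acylguanidine series: removing the amino substituent

A few compounds are considered here, and "the series" means these few. Any claim that something is new, unique, unknown or untested is made for them only; others in the source may bear on it.

Of the compounds shown here, three of a shared acylguanidine core have been measured in a functional assay for inhibition of sodium/hydrogen exchanger (Oryctolagus cuniculus); on this read-out higher numbers stand for weaker inhibition and lower numbers for stronger inhibition. Compound 1 `Cc1cc(-c2cc(Cl)cc(Cl)c2)c(S(C)(=O)=O)cc1C(=O)N=C(N)N` gives 130 nM, compound 2 `Cc1cc(Sc2ccccc2)c(S(C)(=O)=O)cc1C(=O)N=C(N)N` gives 14 nM, and compound 3 `Cc1cc(N)c(S(C)(=O)=O)cc1C(=O)N=C(N)N` gives 16 nM. Compound 3 stands second highest of the three numbers; its nearest neighbour is compound 2, the pair being within the scatter, and its furthest is compound 1, beyond the scatter.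

Compound 4 `Cc1ccc(S(C)(=O)=O)cc1C(=O)N=C(N)N` differs from compound 3 in one place: hydrogen in place of amino on an aromatic carbon, ortho to a methylsulfonyl group. Among the compounds with values here, two measured steps touch this position. Both an 8.1-fold lower number from compound 1 to compound 3 (0.91 log units; beyond the scatter) and a 9.3-fold lower number from compound 1 to compound 2 (0.97 log units; beyond the scatter) show that replacing the 3,5-dichlorophenyl substituent lowers the number in this assay, while a 1.1-fold higher number from compound 2 to compound 3 (0.06 log units; within the scatter) shows that amino and phenylsulfanyl give numbers within the scatter of each other. Within the data shown here, no measured step removes the substituent entirely, so the effect of a bare hydrogen at this carbon is not directly covered. The position tolerates two very different groups without a shift beyond the scatter, so for compound 4 a step of a 2.5-fold higher number from compound 3 to compound 4 (0.40 log units; beyond the scatter) is expected, most likely a small rise in this assay rather than none. Compound 4 is therefore estimated at 40 nM in this assay, with a range from 10 nM to 200 nM.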

Compound 4, half-maximal inhibitory concentration: 150 nM
Estimate against measurement, compound 4: 3.8-fold (0.57 log units) below; the measured number falls inside the stated range.
By their numbers in this assay, from the lowest: compounds 2 and 3 (each within the scatter of the next); then compounds 1 and 4 (each within the scatter of the next).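

Read directly in this assay, the bare aromatic carbon now has a measured reference point: a 9.4-fold higher number from compound 3 to compound 4 (0.97 log units; beyond the scatter) and an 11-fold higher number from compound 2 to compound 4 (1.03 log units; beyond the scatter) show that amino and phenylsulfanyl each go with a clearly lower number than hydrogen at this carbon, ortho to the methylsulfonyl group. In contrast, a 1.2-fold higher number from compound 1 to compound 4 (0.06 log units; within the scatter) leaves 3,5-dichlorophenyl and hydrogen indistinguishable here, so the earlier drops from compound 1 now read as gains over the level of the unsubstituted carbon, and compound 1 stands as the exception to any rule that a substituent here lowers the number. No measured evidence accounts for this difference between the substituents.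

Compound 1 and compound 2 differ both in the sulfur atom joining the outer phenyl ring and in the two chlorines, so a plain phenyl group or a 3,5-dichlorophenylsulfanyl group at this carbon would be needed to separate those two features. From the compounds shown here alone, it also remains open how far the lower numbers extend to close relatives of the two favourable groups, such as methylamino, dimethylamino, phenoxy or methylsulfanyl.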